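The compounds below may be only part of what the source reports. "The series", "measured", "known", "first", "only" and "open" are said of these compounds alone.

Measured so far:
compound 1, `CCN1CCc2c(sc(NC(=O)[C@@H]3CCCN3)c2C(N)=O)C1`; in a functional assay (strain AB) with Danio rerio as the target, read by microscopy, with a stated time of 1 h (a lower number here means that less compound is needed, a higher number that more compound is needed for the effect), compound 1 gives > 25000 nM, a limit of the assay.
compound 2, `CCN1CCc2c(sc(N)c2C(N)=O)C1`; in this assay compound 2 gives > 25000 nM, likewise a limit.
compound 3, `CC(C)(C)C[N+]1(C)CCc2c(sc(NC(=O)Nc3ccc(Cl)cc3)c2C(N)=O)C1`; in this assay compound 3 gives 290 nM.

Compound 1 stands at the limit of this assay, with no number of its own; the same limit, (the limit of > 25000 nM in this assay, at which 2 of the 3 values shown sit), holds two of the three values shown. Among the measured compounds shown here, the only step measured in one place, a step that the two limits leave unreadable from compound 1 to compound 2, runs between two limits and its size cannot be read. The change to compound 4, `CCN1CCc2c(sc(NC(=O)Nc3ccc(Cl)cc3)c2C(N)=O)C1`, is (4-chlorophenyl)amino in place of pyrrolidin-2-yl on a carbonyl carbon. For the measured compounds named here, no measured step covers this exchange, so nothing is known about its size or direction from the series itself. Compound 3 carries the same (4-chlorophenyl)amino on its carbonyl carbon and gives 290 nM in this assay, but compound 3 differs from compound 4 elsewhere as well, so that value serves as a pointer only. The expected step is an at least 16-fold lower number from compound 1 to compound 4 (1.22 log units; beyond the scatter), from a limit toward a readable number, taken as an expectation rather than a measured fact. For compound 4 the estimate in this assay is 1500 nM, with a range from 250 nM to 12000 nM, and a fair chance that compound 4 too reports only a limit.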

Compound 4, half-maximal effective concentration: 3120 nM
The estimate for compound 4 lay 2.1-fold (0.32 log units) below the measured number; low and high end bracket the measured number.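

With the rest of compound 1 unchanged, the group on the carbonyl carbon is now seen to govern the read-out in this assay, as (4-chlorophenyl)amino in place of pyrrolidin-2-yl gives an at least 8.0-fold lower number from compound 1 to compound 4 (0.90 log units; beyond the scatter) in a single exchange. Among the compounds shown here, this is the only readable step so far; the step to compound 2 joins two limits and cannot be read. Its size is only a lower bound, with the compound 1 end resting on an assay limit: the limit of > 25000 nM in this assay, at which 2 of the 4 values shown sit.

The compounds shown leave open which part of (4-chlorophenyl)amino carries the step; phenylamino without the chlorine, 4-methoxyphenylamino or benzylamino on the same carbonyl carbon would separate the aromatic ring from its chlorine and from its distance to the carbonyl. Also open, from the compounds shown here alone, is whether an open-chain group such as butylamino, or a carboxylic acid on the aromatic ring, would keep a readable number in this assay on the core of compound 4.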